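Semicarbazide tail variation: step from compound 3 to compound 4

A few compounds are considered here, and "the series" means these few. Any claim that something is new, unique, unknown or untested is made for them only; others in the source may bear on it.

Measured so far:
- compound 1, `COc1cc(NC(C)CCCNC(=O)Nc2ccc(Cl)c(C(F)(F)F)c2)c2ncccc2c1`, in a physicochemical assay for inhibition, read by spectrophotometry, tested at 100 uM (a higher number here means more inhibition at the concentration tested (going by the name of the read-out), a lower number less inhibition), gives 61%
- compound 2, `COc1cc(NC(C)CCCNC(=O)NN)c2ncccc2c1`, in this assay gives 70%
- compound 3, `COc1cc(NC(C)CCCNC(=O)NNC(=O)NCCO)c2ncccc2c1`, in this assay gives 27%

Compound 3 stands lowest of the three numbers in this assay. Its nearest neighbour is compound 1, with a number 34 percentage points lower from compound 1 to compound 3 (beyond the scatter), and its furthest is compound 2, with a number 43 percentage points lower from compound 2 to compound 3 (beyond the scatter); both steps lie beyond the scatter, so the number for compound 3 is lower than that of either other measured compound. Between compound 1 and compound 2 the step is a number 9 percentage points higher from compound 1 to compound 2 (within the scatter).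

Compound 4, `COc1cc(NC(C)CCCNC(=O)NNC(=O)NC(CO)(CO)CO)c2ncccc2c1`, differs from compound 3 in one place: 2-hydroxy-1,1-bis(hydroxymethyl)ethyl in place of 2-hydroxyethyl on an amide-type nitrogen. Among the compounds with values here, no measured step changes the group on this amide-type nitrogen while keeping the ((2-hydroxyethyl)carbamoyl)amino arrangement; the two steps that reach compound 3, from compound 1 and from compound 2, both bring the ((2-hydroxyethyl)carbamoyl)amino or (2-hydroxyethyl)carbamoyl group in and both are large falls. Nothing measured shows what enlarging the 2-hydroxyethyl part to 2-hydroxy-1,1-bis(hydroxymethyl)ethyl does, so no step beyond the scatter is expected in this assay, and compound 4 is estimated near compound 3.

For compound 4 the expected value in this assay is 22%, within 5% to 42%. The expected step is a number 5 percentage points lower from compound 3 to compound 4 (within the scatter), within the scatter.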

Compound 4, a percentage reported as inhibition, at one concentration (the size of the read-out at that concentration, not a potency): 49%
The estimate for compound 4 lay 27 percentage points below the measured number, outside the stated range (above it).
By their numbers in this assay, from the lowest: compound 3; then compound 4; then compounds 1 and 2 (each within the scatter of the next).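

In this assay, the end group on this amide-type nitrogen proves able to shift the read-out: 2-hydroxy-1,1-bis(hydroxymethyl)ethyl in place of 2-hydroxyethyl gives a number 22 percentage points higher from compound 3 to compound 4 (beyond the scatter), so the low number of compound 3 is not fixed by the carbamoyl extension alone. The recovery is only partial, since the larger group still leaves a number 21 percentage points lower from compound 2 to compound 4 (beyond the scatter) when it enters as (2-hydroxy-1,1-bis(hydroxymethyl)ethyl)carbamoyl on the amine nitrogen, and a number 12 percentage points lower from compound 1 to compound 4 (beyond the scatter) when the whole ((2-hydroxy-1,1-bis(hydroxymethyl)ethyl)carbamoyl)amino unit replaces 4-chloro-3-(trifluoromethyl)phenyl. No measurement at hand bears on why the larger group raises the number.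

The compounds shown leave open whether the rise follows the added hydroxymethyl arms or the branched carbon that carries them, which a tert-butyl group or a 2,3-dihydroxypropyl group on the same nitrogen would separate. Going by these compounds, it also remains open how a longer chain such as 3-hydroxypropyl, or a chain ending in an amine or a carboxylic acid, would read at this position.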